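The source may hold more compounds than are shown below. What is called first, only, known or untested is meant among the compounds shown, and "the series" means these compounds.

Of the compounds shown here, three built on one shared core have been measured in a functional assay on NCI-H3122 cells (Homo sapiens) for antiproliferative activity, read by MTT assay, with a stated time of 48 h; a higher number here means a weaker inhibitor, a lower number a stronger inhibitor. Compound 1 `CC(Oc1cccnc1Nc1cnn(C)c1)c1cccc(C(=O)NCc2ccc(OC(F)(F)F)cc2)c1` gives 8300 nM in this assay. Going by the values given here, compound 2 `CC(Oc1cccnc1Nc1cnn(C)c1)c1cccc(C(=O)NCc2ccc(F)c(Cl)c2)c1` gives 35700 nM in this assay, and the only single-point step among the measured compounds is a 4.3-fold higher number from compound 1 to compound 2 (0.63 log units; beyond the scatter). Compound 3 `Cc1ccc(CNC(=O)c2cccc(C(C)Oc3cccnc3Nc3cnn(CC(C)(C)O)c3)c2)cc1` gives 9100 nM in this assay, the second highest of the three numbers, within the scatter of compound 1 and clearly apart from compound 2.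

Compound 4 `Cc1ccc(CNC(=O)c2cccc(C(C)Oc3cccnc3Nn3cnnc3)c2)cc1` differs from compound 3 by 4H-1,2,4-triazol-4-yl in place of 1-(2-hydroxy-2-methylpropyl)-1H-pyrazol-4-yl on a nitrogen on an aromatic ring. Among the compounds with values here, no measured step bears on this change: the one measured step concerns a different part of the molecule, and compounds 1 and 3, which differ in the group carried on the 1H-pyrazol-4-yl fragment, show numbers within the scatter of each other. The change removes a fragment with one hydrogen-bond donor and puts in a smaller ring with none; with nothing measured to lean on, a modest move toward a higher number is expected, with wide uncertainty. Compound 4 is therefore estimated at 25000 nM, between 8000 nM and 80000 nM, which means an expected step of a 2.7-fold higher number from compound 3 to compound 4 (0.44 log units; beyond the scatter).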

Compound 4, half-maximal inhibitory concentration: 23700 nM
The estimate for compound 4 lay 1.1-fold (0.02 log units) above the measured number, within the range that was stated.
By their numbers in this assay, from the lowest: compounds 1 and 3 (each within the scatter of the next); then compounds 4 and 2 (each within the scatter of the next).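

In this assay, going by these compounds alone, the group on the nitrogen on an aromatic ring, which the earlier compounds showed only as 1H-pyrazol-4-yl fragments, proves sensitive to an exchange of the whole ring: 4H-1,2,4-triazol-4-yl in place of 1-(2-hydroxy-2-methylpropyl)-1H-pyrazol-4-yl gives a 2.6-fold higher number from compound 3 to compound 4 (0.42 log units; beyond the scatter), a modest loss of inhibition. The entering group is smaller and carries no hydrogen-bond donor, so size and donor count change together, and this single pair cannot separate them. No measurement shown accounts for the step.

The compounds shown leave open whether the loss follows the ring itself or the missing 2-hydroxy-2-methylpropyl chain. A 1H-pyrazol-4-yl fragment carrying an amine or a carboxylic acid on a longer chain, or an unsubstituted 1H-pyrazol-4-yl, would bear on that question.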